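The source may report more compounds than this note shows. Statements on the series, on what has been measured and on what is new or still open speak of the compounds shown alone.

In a functional assay on HT-29 cells (Homo sapiens) for inhibition, read by sulforhodamine B assay, with a stated time of 48 h (on this read-out higher numbers stand for weaker inhibition and lower numbers for stronger inhibition), compound 1 (`CCNC(=O)Nc1ccc(/C=C/c2cccc(Cl)c2)cc1`) gives > 20000 nM, which is a limit and not a number. Among the measured compounds shown here, compound 2 (`CCNC(=O)Nc1ccc(/C=C\c2cc(C)cc(C)c2)cc1`) gives 11000 nM, the only actual number so far in this assay. Compound 3 (`Cc1cc(C)cc(/C=C\c2ccc(N3CCNC3=O)cc2)c1`) has 2-oxoimidazolidin-1-yl in place of (ethylcarbamoyl)amino on an aromatic carbon. For the measured compounds named here, no measured step covers this exchange, so no direction is favoured. The expected 1.3-fold higher number from compound 2 to compound 3 (0.10 log units; within the scatter) stays within the usual scatter. Compound 3 is estimated at 14000 nM, with an expected range of 5000 nM to 30000 nM.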

Compound 3, half-maximal inhibitory concentration: 8.4 nM
The estimate for compound 3 lay 1700-fold (3.22 log units) above the measured number, outside the stated range (below it).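

In this assay, 2-oxoimidazolidin-1-yl in place of (ethylcarbamoyl)amino, on an aromatic carbon para to a large group, gives a 1300-fold lower number from compound 2 to compound 3 (3.12 log units; beyond the scatter). The two groups have the same heavy-atom count and differ in the five-membered ring and in hydrogen-bond donor count, so this position separates closely matched groups sharply. Compound 1 stands at a limit and not a number, and gives no step: the limit of > 20000 nM in this assay, at which 1 of the 3 values shown sits.

Among the compounds shown here, the single pair cannot separate the ring from the donor count. On these data alone, whether a methyl group on the ring nitrogen carrying hydrogen, or a six-membered ring, would keep this level remains open.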